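This account rests on a few compounds, and the source may have more. Where it says the series, first, only, none or still open, it means among the compounds named here.

Values in a functional assay on SiHa cells (Homo sapiens) for inhibition, read by sulforhodamine B assay; a lower number here means a stronger inhibitor of growth, a higher number a weaker inhibitor of growth:
- Compound 1 `FC(F)(F)Oc1ccc(-c2ccc(-c3ccc(-c4nc5ccccc5[nH]4)cc3)cc2)cc1`: 38400 nM
- Compound 2 `Oc1ccc(-c2ccc(-c3ccc(-c4nc5ccccc5[nH]4)cc3)cc2)cc1`: 33300 nM
- Compound 3 `Oc1cccc2[nH]c(-c3ccc(-c4ccc(-c5ccc(OC(F)(F)F)cc5)cc4)cc3)nc12`: not yet measured

Among the measured compounds shown here, compound 1 holds the higher of only two numbers, but compound 2 lies within the scatter of it, so no real ranking exists. Compound 3 keeps the trifluoromethyl group of compound 1 and changes the other end of the molecule: hydroxy in place of hydrogen on an aromatic carbon. In words, this is hydroxy in place of hydrogen on an aromatic carbon, turning 1H-benzimidazol-2-yl into 4-hydroxy-1H-benzimidazol-2-yl. For the measured compounds named here, no measured step covers this place. Going by the values given here, the one step available, a 1.2-fold lower number from compound 1 to compound 2 (0.06 log units; within the scatter), also introduces a hydroxy group, but at a different place, so it is only weak guidance. No change beyond the scatter is therefore expected in this assay, though the uncertainty is wide. The expected step is a 1.5-fold lower number from compound 1 to compound 3 (0.19 log units; within the scatter). For compound 3 the estimate is 25000 nM, with an expected range of 8000 nM to 60000 nM.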

Compound 3, concentration for 50% growth inhibition: 8410 nM
The estimate for compound 3 lay 3.0-fold (0.47 log units) above the measured number; measured number inside the range.
By their numbers in this assay, from the lowest: compound 3; then compounds 2 and 1 (each within the scatter of the next).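

Hydroxy in place of hydrogen on an aromatic carbon, turning 1H-benzimidazol-2-yl into 4-hydroxy-1H-benzimidazol-2-yl, gives the first step beyond the scatter in this series in this assay: a 4.6-fold lower number from compound 1 to compound 3 (0.66 log units; beyond the scatter). The earlier step, a 1.2-fold lower number from compound 1 to compound 2 (0.06 log units; within the scatter), left a hydroxy group on the other end of the molecule, in place of the trifluoromethyl on oxygen, within the scatter, so in these two pairs the outcome depends on where the hydroxy group stands. No measurement available here accounts for the size of the new step.

Whether the step needs hydroxy itself stays open, as a methoxy group, an amine or a fluorine on the same carbon is not among the compounds shown. Also open, from the compounds shown here alone, is whether the same change would give a similar step on the core of compound 2.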